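The source may report more compounds than this note shows. Statements on the series, on what has been measured and on what is new or still open speak of the compounds shown alone.

Going by the values given here, in an ADME assay for permeability, using PAMPA, at pH 4 (a lower number here means that the compound crosses the layer more slowly, a higher number that the compound crosses the layer faster), compound 1 `Cc1[nH]c2ccccc2c(=O)c1Br` gives 8.19 10^-6 cm/s, and compound 2 `Cc1ccc2[nH]c(C)c(Br)c(=O)c2c1` gives 26.4 10^-6 cm/s, the higher of the only two numbers available so far. Among the compounds with values here, the single measured step between them is a 3.2-fold higher number from compound 1 to compound 2 (0.51 log units; beyond the scatter), a modest change that goes with methyl in place of hydrogen on an aromatic carbon.

Compound 3 `Cc1[nH]c2ccc(Br)cc2c(=O)c1Br` alters that same carbon again, with bromo in place of methyl on an aromatic carbon. Within the data shown here, the one measured step, a 3.2-fold higher number from compound 1 to compound 2 (0.51 log units; beyond the scatter), is the only guide here, and it compares methyl with hydrogen, not with bromo. Among the measured compounds shown here, no measured pair shows how bromo on this carbon compares with either group, so the data point in no clear direction.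

The expected step in this assay is therefore small, and the estimate is a 1.1-fold lower number from compound 2 to compound 3 (0.04 log units; within the scatter), with no change beyond the scatter expected. The range stays wide, since it rests on so little. Compound 3 is estimated at 24 10^-6 cm/s, with an expected range from 10 10^-6 cm/s to 55 10^-6 cm/s.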

Compound 3, apparent permeability: 133 10^-6 cm/s
Estimate against measurement, compound 3: 5.5-fold (0.74 log units) below; measured number above the stated range.
By their numbers in this assay, from the lowest: compound 1; then compound 2; then compound 3.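

At this one aromatic carbon, the choice of group matters more than the first pair could reveal: in this assay there is a 5.0-fold higher number from compound 2 to compound 3 (0.70 log units; beyond the scatter) even though methyl and bromo each count as a single heavy atom, and neither brings a hydrogen-bond donor, a hydrogen-bond acceptor or a net charge. Measured against hydrogen, bromo gives a 16-fold higher number from compound 1 to compound 3 (1.21 log units; beyond the scatter) and so goes well past the modest 3.2-fold higher number from compound 1 to compound 2 (0.51 log units; beyond the scatter) seen with methyl, which places the three groups at this carbon in the order hydrogen, methyl, bromo, with every step beyond the scatter. No measurement available here gives a reason for that order.

The three compounds cannot tell whether the rise belongs to bromo alone or would also appear with chloro or fluoro, and they say nothing about how an amine, a methoxy group or a carboxylic acid would behave on this carbon. Going by these compounds, all three also share the same core with its second bromo, so it stays open whether this order would hold on a core without that atom.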